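The source may report more compounds than this note shows. Statements on the series, on what has been measured and on what is new or still open speak of the compounds shown alone.

Working notes on the step from compound 2 to compound 3. In an ADME assay on Huh-7 cells (Homo sapiens) for cytotoxicity, read by MTT assay, with a stated time of 72 h (a higher number here means that more compound is tolerated, a lower number that less compound is tolerated), compound 2 (`C/C(=C\c1c[nH]c2ccccc12)C(=O)NCCN(C)C`) reads > 100000 nM and this is a limit of the assay, not a number. On the same core, compound 1 (`C/C(=C\c1c[nH]c2ccccc12)C(=O)NCc1ccco1`) gives a true number of 39100 nM in this assay and is the only numerical anchor so far.

Compound 3 (`C/C(=C\c1c[nH]c2ccccc12)C(=O)NCCCn1ccnc1`) carries (1H-imidazol-1-yl)methyl in place of dimethylamino on a saturated chain carbon, two bonds along the chain from an amide-type nitrogen.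

For the measured compounds named here, only one measured step bears on this change: an at least 2.5-fold higher number from compound 1 to compound 2 (0.40 log units; beyond the scatter) and its size is known only in part. That step ends on a limit (the limit of > 100000 nM in this assay, at which 1 of the 2 values shown sits). Compound 3 brings back a five-membered aromatic ring, as furan-2-yl does in compound 1 at 39100 nM so a lower number in this assay is expected, of about the size of that step taken in reverse. The expected change is an at least 1.4-fold lower number from compound 2 to compound 3 (0.15 log units; that floor lies within the scatter) in this assay and a reading at the limit remains possible. Compound 3 is estimated at 70000 nM (expected range 30000 nM to 100000 nM).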

Compound 3, half-maximal cytotoxic concentration: > 100000 nM
Compound 3 gave a limit, no number (the forecaster's own chance of this, stated with the estimate: 35%); middle value at least 1.4-fold (0.15 log units) from the limit.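

In this assay, the furan-2-yl of compound 1 and the 2-(1H-imidazol-1-yl)ethyl of compound 3 each carry a five-membered aromatic ring, yet the comparison gives an at least 2.5-fold higher number from compound 1 to compound 3 (0.40 log units; beyond the scatter); a five-membered aromatic ring on this chain therefore does not by itself bring the number down. For the compounds shown here, two different groups at this place, dimethylamino in compound 2 and (1H-imidazol-1-yl)methyl in compound 3, now stand at the limit, so reaching it is not tied to dimethylamino alone, and compound 1 remains the only true number. The step between compound 2 and compound 3 cannot be read, and the position of either compound past the limit is unknown: the limit of > 100000 nM in this assay, at which 2 of the 3 values shown sit.

From the compounds shown here alone, whether the lower number of compound 1 goes with furan-2-yl or with the chain that carries it stays open; compound 3 differs from compound 1 in both at once. A furan-2-yl on a longer chain, or a phenyl or a carboxylic acid on the chain of compound 3, would show which groups give a true number in this assay.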